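The source may report more compounds than this note shows. Statements on the series, on what has been measured and on what is new or still open speak of the compounds shown alone.

The measured compounds:
Compound 1 `Cc1ccnc([C@@H](C)Oc2cc3oc(=O)n(CCC(=O)O)c3cc2Cl)c1`: in an assay on HEK293 cells for inhibition of kynurenine 3-monooxygenase (Homo sapiens), read by LC-MS, with a stated time of 20 h (a higher number here means a weaker inhibitor, a lower number a stronger inhibitor), compound 1 gives 31600 nM.
Compound 2 `CCOc1cc2oc(=O)n(CCC(=O)O)c2cc1Cl`: compound 2 gives 398 nM.
Compound 3 `COCCOc1cc2oc(=O)n(CCC(=O)O)c2cc1Cl`: compound 3 gives 50100 nM.

Compound 2 stands lowest of the three numbers, and both other compounds lie beyond the scatter from it: a 79-fold lower number from compound 1 to compound 2 (1.90 log units; beyond the scatter), and a 130-fold higher number from compound 2 to compound 3 (2.10 log units; beyond the scatter). Compound 4 `Cc1cccc([C@@H](C)Oc2cc3oc(=O)n(CCC(=O)O)c3cc2Cl)n1` differs from compound 2 in one place: 6-methylpyridin-2-yl in place of hydrogen on a saturated chain carbon bound to an oxygen on an aromatic ring and a saturated chain carbon. Among the measured compounds shown here, the step that bears on this change is the one between compound 1 and compound 2, since compound 1 carries 4-methylpyridin-2-yl on the same saturated chain carbon, and removing it gave the large drop already described. Putting 6-methylpyridin-2-yl there is therefore expected to reverse much of that gain, and compound 4 is expected to show a large upward step, a 63-fold higher number from compound 2 to compound 4 (1.80 log units; beyond the scatter). The estimate for compound 4 in this assay is 25000 nM, with a range from 6000 nM to 80000 nM.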

Compound 4, half-maximal inhibitory concentration: 316 nM
For compound 4 the middle estimate is 79-fold (1.90 log units) above the measured one; measured number below the stated range.
By their numbers in this assay, from the lowest: compounds 4 and 2 (each within the scatter of the next); then compounds 1 and 3 (each within the scatter of the next).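

In this assay the saturated chain carbon bound to an oxygen on an aromatic ring and a saturated chain carbon carries 6-methylpyridin-2-yl with no loss against hydrogen, as the step shows: a 1.3-fold lower number from compound 2 to compound 4 (0.10 log units; within the scatter). The large loss seen with 4-methylpyridin-2-yl therefore does not extend to every methylpyridinyl group at this place, and exchanging only that group for 6-methylpyridin-2-yl gives a 100-fold lower number from compound 1 to compound 4 (2.00 log units; beyond the scatter), so the placement of the methyl group on the ring decides the result among these compounds. Nothing at hand accounts for the gap between these two groups.

The compounds shown leave open how pyridin-2-yl without a methyl group, or a phenyl ring, would read at this carbon. They also leave open whether a 6-methoxypyridin-2-yl group would read like 6-methylpyridin-2-yl.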